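Returning from benzyl to an aryl amide

The source may hold more compounds than are shown below. What is called first, only, known or untested is meant among the compounds shown, and "the series" means these compounds.

Compound 1 `O=C(Nc1ccccc1)c1csc(-c2c[nH]c3ccccc23)n1` in a functional assay on MDA-MB-231 cells (Homo sapiens) for cytotoxicity, read by MTT assay, with a stated time of 48 h, in the absence of a further agent (a lower number here means a stronger inhibitor, a higher number a weaker inhibitor), gives 79400 nM.
Compound 2 `O=C(NCc1ccccc1)c1csc(-c2c[nH]c3ccccc23)n1` gives > 100000 nM, a limit of the assay.
Compound 3 `COc1cc(NC(=O)c2csc(-c3c[nH]c4ccc(F)cc34)n2)cc(OC)c1OC` gives > 100000 nM, also a limit.

Compound 2 thus stands at the limit of > 100000 nM in this assay, at which 2 of the 3 values shown sit, with no number of its own. For the measured compounds named here, the only measured step that touches it is an at least 1.2-fold higher number from compound 1 to compound 2 (0.10 log units; that floor lies within the scatter), small and within the scatter. Compound 4 `Cc1ccc(NC(=O)c2csc(-c3c[nH]c4ccccc34)n2)cc1` is made from compound 2 by 4-methylphenyl in place of benzyl on an amide-type nitrogen. This reverses the benzyl change and adds a methyl group on the ring, so compound 4 is expected to behave much like compound 1, whose value is 79400 nM. Compound 4 is therefore estimated at 80000 nM, between 30000 nM and 200000 nM. That expected step, an at least 1.2-fold lower number from compound 2 to compound 4 (0.09 log units; that floor lies within the scatter), would barely exceed the scatter, and a second limit remains quite possible.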

Compound 4, half-maximal inhibitory concentration: > 100000 nM
Compound 4 gave a limit, no number (the forecaster's own chance of this, stated with the estimate: 45%); middle value at least 1.2-fold (0.09 log units) away from the limit.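

In this assay, methyl in place of hydrogen on an aromatic carbon gives an at least 1.2-fold higher number from compound 1 to compound 4 (0.10 log units; that floor lies within the scatter), so the 4-methylphenyl amide shows no gain over the phenyl amide of compound 1. The step from compound 2 to compound 4 cannot be read, so benzyl and 4-methylphenyl on the amide nitrogen cannot be ranked. The value of compound 4 is a limit, and most of the series now rests there: the limit of > 100000 nM in this assay, at which 3 of the 4 values shown sit.

From the compounds shown here alone, it remains open whether an amine or a carboxylic acid in place of the methyl group of compound 4 would give a number rather than a limit. Going by these compounds, how far compound 2 and compound 4 lie beyond their limits also remains open.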